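Acylating the Aniline Nitrogen of a Furyl Chalcone

A few compounds are considered here, and "the series" means these few. Any claim that something is new, unique, unknown or untested is made for them only; others in the source may bear on it.

Measured so far:
compound 1, `Nc1ccc(C(=O)/C=C/c2ccco2)cc1`, 42%
compound 2, `COc1ccc(/C=C/C(=O)c2ccc(NC(=O)CBr)cc2)cc1`, 46%

In a functional assay on the whole organism (strain albino) for inhibition, with Rattus norvegicus as the target, read by paw edema, with stated times of 30 min and 3 h, at a dose of 100 mg/kg by the oral route (on this read-out higher numbers stand for more inhibition at the one dose given (going by the name of the read-out) and lower numbers for less inhibition), compound 1 gives 42%, and compound 2 gives 46%. The two numbers sit within the usual scatter of each other, so the inhibition in this assay is level between them, and as they differ in more than one place no single step can be read between them.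

Compound 3, `CC(Br)C(=O)Nc1ccc(C(=O)/C=C/c2ccco2)cc1`, differs from compound 1 in one place: (1-bromoethyl)carbonyl in place of hydrogen on a nitrogen on an aromatic ring. The nitrogen of compound 1 keeps one hydrogen and gains a carbonyl bearing the 1-bromoethyl chain. Compound 2 also carries an acylated nitrogen and gives 46%, which gives no sign of a large move in either direction.

The step of a number 4 percentage points higher from compound 1 to compound 3 (within the scatter) is therefore expected to be small, perhaps upward, and within the scatter. Compound 3 is expected to give 46%, somewhere between 32% and 60%.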

Compound 3, a percentage reported as inhibition, in the whole organism at one dose (the size of the read-out at that dose, not a potency): 42%
Beside the measured number, compound 3's estimate is 4 percentage points above it; measured number inside the range.
By their numbers in this assay, from the lowest: compounds 1, 3 and 2 (each within the scatter of the next).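

In this assay, placing (1-bromoethyl)carbonyl in place of hydrogen on a nitrogen on an aromatic ring gives no change at the digits printed from compound 1 to compound 3 (within the scatter). Among the compounds shown here, this is the first direct comparison at this nitrogen, and it shows that the free amino group and the ((1-bromoethyl)carbonyl)amino group read level at this single dose, so the amino hydrogen can be replaced by this acyl group with no visible effect on the read-out. Nothing available explains why the read-out stays level.

The compounds shown leave open whether the bromine plays any part at this nitrogen, since an acetyl group, which has no bromine, or a longer chain on the same carbonyl could read the same or differently. A reading at one dose is also not a potency, so compounds that read level here could still separate at other doses.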